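Swapping a phenyl for an imidazolyl-sulfanyl-methyl arm

The compounds below may be only part of what the source reports. "The series", "measured", "known", "first", "only" and "open" are said of these compounds alone.

Of the compounds shown here, two sharing the same core have been measured in an assay for inhibition of Amine oxidase [flavin-containing] B (Homo sapiens), read by fluorescence and spectrophotometry, using microsomes, with stated times of 30 min and 20 min; on this read-out lower numbers stand for stronger inhibition and higher numbers for weaker inhibition. Compound 1 `c1ccc(Oc2ccc(-c3noc(-c4ccc(C5=NCCN5)cc4)n3)cc2)cc1` gives 1370 nM. For the measured compounds named here, compound 2 `c1ccc(-c2ccc(-c3noc(-c4ccc(C5=NCCN5)cc4)n3)cc2)cc1` gives 47600 nM, the higher of the two numbers, and the only recorded step leads to it: a 35-fold higher number from compound 1 to compound 2 (1.54 log units; beyond the scatter). Compound 3 `Cn1ccnc1SCc1ccc(-c2noc(-c3ccc(C4=NCCN4)cc3)n2)cc1` differs from compound 2 in one place: ((1-methyl-1H-imidazol-2-yl)sulfanyl)methyl in place of phenyl on an aromatic carbon.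

Going by the values given here, only the step from compound 1 to compound 2 bears on this change, and it was large. It shows that the group at this position matters strongly, and that the phenyl of compound 2 gives the weaker result, while a group carrying a linking atom before its ring gave the stronger one. The entering group also carries a linker before its ring, so a move back toward the stronger side is expected for compound 3, though its size is uncertain because the ring itself differs from that of compound 1 in 1370 nM. For compound 3 the expected step is a 7.9-fold lower number from compound 2 to compound 3 (0.90 log units; beyond the scatter), and its estimated value is 6000 nM, with a range from 800 nM to 40000 nM.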

Compound 3, half-maximal inhibitory concentration: 2280 nM
Compound 3: middle estimate off by 2.6-fold (0.42 log units), on the high side; low and high end bracket the measured number.
By their numbers in this assay, from the lowest: compounds 1 and 3 (each within the scatter of the next); then compound 2.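

Replacing the phenyl with the ((1-methyl-1H-imidazol-2-yl)sulfanyl)methyl arm gives a 21-fold lower number from compound 2 to compound 3 (1.32 log units; beyond the scatter) in this assay, so the weak result of compound 2 does not come from the shared core alone, and a five-membered aromatic ring with 2 hetero atoms can stand at the end of this arm without loss. Set against the phenoxy group, the same arm gives a 1.7-fold higher number from compound 1 to compound 3 (0.22 log units; within the scatter), so two quite different groups cannot be told apart on this read-out, and among these three compounds only the phenyl, joined directly to the ring that carries it, stands apart with the higher number. Nothing available here explains why this position responds in this way.

The sulfur, the methylene and the imidazole ring all entered together, so the compounds shown cannot say which of them accounts for the large step, and a phenylsulfanylmethyl arm would begin to separate them. As far as these compounds go, it also remains open how a benzyloxy group, an amine or a longer chain at this aromatic carbon would compare.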